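Methoxy in place of chloro on the fused ring

A few compounds are considered here, and "the series" means these few. Any claim that something is new, unique, unknown or untested is made for them only; others in the source may bear on it.

Three compounds share one core and differ only on a single aromatic carbon of a fused ring. Compound 1 `CS(=O)(=O)c1ccc(Nc2ncc(F)c(Nc3nc4ccccc4s3)n2)cc1` carries hydrogen there; in a functional assay on MCF7 cells (Homo sapiens) for antiproliferative activity, read by MTT assay, with a stated time of 48 h (on this read-out higher numbers stand for weaker inhibition and lower numbers for stronger inhibition), compound 1 gives 6880 nM. Compound 2 `Cc1ccc2nc(Nc3nc(Nc4ccc(S(C)(=O)=O)cc4)ncc3F)sc2c1` carries methyl there. In this assay compound 2 gives > 50000 nM, which is a limit of the assay and not a number. Compound 3 `CS(=O)(=O)c1ccc(Nc2ncc(F)c(Nc3nc4ccc(Cl)cc4s3)n2)cc1` carries chloro there. In this assay compound 3 gives > 50000 nM, again a limit rather than a number, so compound 3 sits at the limit of > 50000 nM in this assay, at which 2 of the 3 values shown sit. Adding a group to that carbon cost activity both times: an at least 7.2-fold higher number from compound 1 to compound 2 (0.86 log units; beyond the scatter) and an at least 7.2-fold higher number from compound 1 to compound 3 (0.86 log units; beyond the scatter). Between the two limits, a step that the two limits leave unreadable from compound 2 to compound 3 cannot be read. Compound 4 `COc1ccc2nc(Nc3nc(Nc4ccc(S(C)(=O)=O)cc4)ncc3F)sc2c1` is the next member: methoxy in place of chloro on an aromatic carbon. Going by these compounds, because an at least 7.2-fold higher number from compound 1 to compound 2 (0.86 log units; beyond the scatter) and an at least 7.2-fold higher number from compound 1 to compound 3 (0.86 log units; beyond the scatter) both carried the number beyond what the assay reports, a third substituent on this carbon is expected to behave similarly, though a methoxy is untested and a partial recovery cannot be excluded. The step of an at least 1.2-fold lower number from compound 3 to compound 4 (0.09 log units; that floor lies within the scatter) is therefore expected to be small or absent. Compound 4 is estimated at 40000 nM, within 7000 nM to 200000 nM, with a fair chance that only a limit is reported.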

Compound 4, half-maximal inhibitory concentration: 5850 nM
The estimate for compound 4 lay 6.8-fold (0.83 log units) above the measured number, outside the stated range (below it).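

In this assay, methoxy on this carbon gives an at least 8.5-fold lower number from compound 3 to compound 4 (0.93 log units; beyond the scatter) and an at least 8.5-fold lower number from compound 2 to compound 4 (0.93 log units; beyond the scatter), so the loss seen with methyl and chloro is not shared by every group placed here. Against the bare carbon of compound 1, the change gives a 1.2-fold lower number from compound 1 to compound 4 (0.07 log units; within the scatter), which means that methoxy is tolerated here, with neither a gain nor a loss that can be told apart from ordinary assay scatter. The steps from compound 2 and compound 3 are minimum sizes rather than exact ones, because each starts from a limit and not a number: the limit of > 50000 nM in this assay, at which 2 of the 4 values shown sit.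

Going by these compounds, what sets methoxy apart from methyl and chloro stays open: methoxy enters with one hydrogen-bond acceptor where chloro has none, but three substituents cannot show whether that count matters, and the step between the two limits cannot be read. Nor do the compounds shown tell whether an ethoxy, a hydroxyl or an amine on this carbon would stay level with compound 1 or fall to the limit, as methyl and chloro do.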